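A few compounds are considered here, and "the series" means these few. Any claim that something is new, unique, unknown or untested is made for them only; others in the source may bear on it.

Among the compounds with values here, in an assay on NK92 cells for inhibition of interleukin-2 (Homo sapiens), read by AlphaScreen, with stated times of 30 min and 1 h (on this read-out lower numbers stand for stronger inhibition and higher numbers for weaker inhibition), compound 1 `Cn1c(Cc2nn(C)c(=O)c3ccccc23)nnc1SCCCCCCCC(=O)Nc1ccc(Cl)cc1Cl` gives 350 nM, the only plain number among the values shown. Compound 2 `Cn1nc(Cc2nnc(SCCCCCCCC(=O)Nc3ccc(Cl)cc3Cl)n2CCCO[Si](C)(C)C(C)(C)C)c2ccccc2c1=O` reaches only the assay limit of > 30000 nM in this assay, which is a limit and not a number. The step of an at least 85-fold higher number from compound 1 to compound 2 (1.93 log units; beyond the scatter) is large, and the limit of > 30000 nM in this assay, at which 1 of the 2 values shown sits, is where compound 2 sits. Compound 3 `Cn1c(Cc2nn(CCCO[Si](C)(C)C(C)(C)C)c(=O)c3ccccc23)nnc1SCCCCCCCC(=O)Nc1ccc(Cl)cc1Cl` differs from compound 1 by a group of 10 heavy atoms (8 carbon, 1 oxygen, 1 silicon; no ring) in place of a hydrogen atom, on a saturated chain carbon bound to an aromatic nitrogen; the same group enters as in compound 2, on a saturated chain carbon bound to an aromatic nitrogen, though at another site of the shared core. Within the data shown here, only the step from compound 1 to compound 2 bears on this change, and it was large and beyond the scatter. A large loss in this assay is therefore expected for compound 3, estimated as a 43-fold higher number from compound 1 to compound 3 (1.63 log units; beyond the scatter). Compound 3 is expected to give about 15000 nM, between 2000 nM and 60000 nM, with a fair chance that only a limit is reported.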

Compound 3, half-maximal inhibitory concentration: > 30000 nM
Compound 3 gave a limit, no number (the forecaster's own chance of this, stated with the estimate: 45%); middle value at least 2.0-fold (0.30 log units) away from the limit.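

In this assay, the group that cost so much at the site changed in compound 2 proves just as costly at a second site of the shared core, with an at least 85-fold higher number from compound 1 to compound 3 (1.93 log units; beyond the scatter). The loss is thus not tied to one attachment point: at both sites tested, this group of 10 heavy atoms on a saturated chain carbon bound to an aromatic nitrogen takes the compound out of the measurable range. Compound 3 gives a limit and not a number, and the two sites cannot be ranked against each other because both compounds stop at the same limit: the limit of > 30000 nM in this assay, at which 2 of the 3 values shown sit.

The compounds shown leave open whether the whole group or only its silicon-bearing end accounts for the loss. A simple ethyl group or a chain ending in a free hydroxyl at either site would separate the two.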